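The source may report more compounds than this note shows. Statements on the series, on what has been measured and on what is new or still open speak of the compounds shown alone.

Measured so far in a functional assay on HeLa cells (Homo sapiens) for antiproliferative activity, with a stated time of 24 h; on this read-out higher numbers stand for weaker inhibition and lower numbers for stronger inhibition:
compound 1, `NC(=O)c1c(NC(=O)c2ccc(C(F)(F)F)cc2)sc2c1CCN(C(=O)Nc1ccccc1Cl)C2`: > 50000 nM
compound 2, `Cc1ccc(C(=O)Nc2sc3c(c2C(N)=O)CCN(C(=O)Nc2ccccc2Cl)C3)cc1`: 32900 nM
compound 3, `NC(=O)c1c(NC(=O)c2cccc([N+](=O)[O-])c2)sc2c1CCN(C(=S)Nc1ccccc1Cl)C2`: 40300 nM

The value of compound 1 in this assay is a limit of the assay, not a number (the limit of > 50000 nM in this assay, at which 1 of the 3 values shown sits). Compound 3 gives a number that lies within the scatter of the number for compound 2, so the two are not separated. Among the compounds with values here, the one step measured in this assay, an at least 1.5-fold lower number from compound 1 to compound 2 (0.18 log units; that floor lies within the scatter), starts from a limit and rests on a floor that is itself within the scatter.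

Compound 4, `NC(=O)c1c(NC(=O)c2cccc([N+](=O)[O-])c2)sc2c1CCN(C(=O)Nc1ccccc1Cl)C2`, differs from compound 3 in one place: a group of 10 heavy atoms (7 carbon, 1 nitrogen, 1 oxygen, 1 chlorine; one six-membered aromatic ring of carbon only) in place of a group of 10 heavy atoms (7 carbon, 1 nitrogen, 1 sulfur, 1 chlorine; one six-membered aromatic ring of carbon only), on an amine nitrogen in a ring. Within the data shown here, no measured step touches this part of the molecule; the single measured step concerns a different group, methyl in place of trifluoromethyl on an aromatic carbon, and its size is an at least 1.5-fold lower number from compound 1 to compound 2 (0.18 log units; that floor lies within the scatter). Nothing measured therefore points to a step beyond the scatter in either direction for compound 4. Compound 4 is expected at 38000 nM, with a range from 15000 nM to 80000 nM. The step of a 1.1-fold lower number from compound 3 to compound 4 (0.03 log units; within the scatter) is thus expected to stay within the scatter.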

Compound 4, half-maximal inhibitory concentration: > 50000 nM
Compound 4: only a limit was reported; the forecaster's own chance of this, stated with the estimate: 35%; middle value at least 1.3-fold (0.11 log units) away from the limit.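

In this assay compound 4 gives > 50000 nM, which is a limit of the assay and not a number: the limit of > 50000 nM in this assay, at which 2 of the 4 values shown sit. Within the data shown here, at the amine nitrogen in a ring, (2-chlorophenyl)carbamoyl in place of the sulfur-containing group gives an at least 1.2-fold higher number from compound 3 to compound 4 (0.09 log units; that floor lies within the scatter), the first reading at this place, and its floor does not separate the two compounds. On the carbonyl carbon, 3-nitrophenyl in place of 4-methylphenyl gives an at least 1.5-fold higher number from compound 2 to compound 4 (0.18 log units; that floor lies within the scatter), again only a floor within the scatter, while the step between compound 1 and compound 4 cannot be read.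

From the compounds shown here alone, how far compound 4 lies past the limit stays open, and with it whether the exchange of sulfur for oxygen exceeds the scatter. Also open, going by these compounds, is how an acetyl group or a longer alkyl chain on that ring nitrogen, or an amine in place of the nitro group, would read in this assay.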